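The source may hold more compounds than are shown below. What is called first, only, known or untested is meant among the compounds shown, and "the series" means these compounds.

Measured in a functional assay on A2780 cells (Homo sapiens) for inhibition, read by sulforhodamine B assay, with a stated time of 72 h; on this read-out lower numbers stand for stronger inhibition and higher numbers for weaker inhibition:
- compound 1 `O=C(NCc1ccc(S(=O)(=O)c2ccccc2C(F)(F)F)cc1)c1cc2cnccc2[nH]1`: 25 nM
- compound 2 `O=C(NCc1ccc(S(=O)(=O)N2CCCCC2)cc1)c1cc2cnccc2o1`: 1500 nM
- compound 3 `O=C(NCc1ccc(S(=O)(=O)c2cccc(C(F)(F)F)c2)cc1)c1cnc2nccn2c1`: 2 nM

Compound 2, at 1500 nM, has the highest number of the three and so shows the weakest inhibition in this assay. Its value lies far above those of the other two compounds.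

The next compound to be tested is compound 4 `O=C(NCc1ccc(S(=O)(=O)N2CCCCC2)cc1)c1cc2ccncc2o1`, which has the same atoms as compound 2, joined differently: a group of 9 heavy atoms (7 carbon, 1 nitrogen, 1 oxygen; one five-membered aromatic ring with 1 hetero atom, one six-membered aromatic ring with 1 hetero atom) in place of a group of 9 heavy atoms (7 carbon, 1 nitrogen, 1 oxygen; one five-membered aromatic ring with 1 hetero atom, one six-membered aromatic ring with 1 hetero atom), on a carbonyl carbon. The rest of the molecule stays the same.

Among the compounds with values here, no measured pair in this small set shows a change of this kind, so the expectation rests on thin evidence. Compound 1 gives 25 nM and compound 3 gives 2 nM, so much lower numbers do occur among these compounds. However, each of them differs from compound 2 in more than one place, and neither value can be read as the effect of this single change.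

A moderate move toward stronger inhibition is expected in this assay, somewhat beyond the scatter, although a step in either direction remains possible. The expected step is a 3.0-fold lower number from compound 2 to compound 4 (0.48 log units; beyond the scatter).

For compound 4, the estimated value is 500 nM, with an expected range from 40 nM to 5000 nM.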

Compound 4, half-maximal inhibitory concentration: 29 nM
Compound 4: middle estimate off by 17-fold (1.24 log units), on the high side, outside the stated range (below it).
By their numbers in this assay, from the lowest: compound 3; then compounds 1 and 4 (each within the scatter of the next); then compound 2.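

Compounds 1 and 3 each differ from compound 2 in more than one place, so they could not show what the group on the carbonyl carbon contributes by itself. In this assay the exchange of one group for its isomer at this place gives a 52-fold lower number from compound 2 to compound 4 (1.71 log units; beyond the scatter) and this large step comes with no change in the counts of heavy atoms, rings, hydrogen-bond donors or hydrogen-bond acceptors, so at this place those counts do not separate a weak compound from a much stronger one, and how the atoms of the group are joined makes the difference in this pair. No measurement shown here offers an explanation for the size of this step.

This single pair leaves open whether the same exchange would give a step of similar size when the rest of the molecule is different, such as the trifluoromethyl-bearing sulfone of compound 1 in place of the sulfonyl group shared by compound 2 and compound 4. It also leaves open how the number would respond to a further substituent on the group at the carbonyl carbon, such as a methoxy group or a primary amine.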